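Carboxy to carbamoyl on the cyclohexyl tail of compound 1

A few compounds are considered here, and "the series" means these few. Any claim that something is new, unique, unknown or untested is made for them only; others in the source may bear on it.

Measured compounds:
- compound 1 `Cc1cccc(Cc2nc3cc(O[C@H]4CC[C@@H](C(=O)O)CC4)ccc3n2C)c1`: 42 nM
- compound 2 `Cc1ccc(Cc2nc3cc(O[C@H]4CC[C@@H](C(=O)O)CC4)ccc3n2C)cc1`: 150 nM
- compound 3 `Cn1c(Cc2cccc(C#N)c2)nc2cc(O[C@H]3CC[C@@H](C(=O)O)CC3)ccc21`: 51000 nM

All three values come from an assay on isolated protein for inhibition of Long-chain-fatty-acid--CoA ligase 1 (Homo sapiens), read by mass spectrometry, with a stated time of 90 min, in the presence of a further agent that is not named here; a lower number here means a stronger inhibitor, a higher number a weaker inhibitor. Compound 1 gives the lowest number of the three in this assay; compound 2 is the nearest, and compound 3 the furthest. The step of a 3.6-fold higher number from compound 1 to compound 2 (0.55 log units; beyond the scatter) is modest, the step of a 1200-fold higher number from compound 1 to compound 3 (3.08 log units; beyond the scatter) is large, and the step of a 340-fold higher number from compound 2 to compound 3 (2.53 log units; beyond the scatter) is also large. Every one of these steps changes the aryl group on the benzylic carbon and leaves the cyclohexyl acid untouched.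

Compound 4 `Cc1cccc(Cc2nc3cc(O[C@H]4CC[C@@H](C(N)=O)CC4)ccc3n2C)c1` differs from compound 1 in a different place: amino in place of hydroxy on a carbonyl carbon. The change is the carboxy to carbamoyl exchange on the 4-carboxycyclohexyl, the carbonyl carbon in question being otherwise bound only to a saturated ring carbon. Going by the values given here, none of the measured steps bears on this part of the molecule, so the series gives no direct read on it; the aryl steps only show that this assay responds strongly to changes elsewhere. The expectation is therefore uncertain and wide. Compound 4 is expected to weaken, with the step of a 9.5-fold higher number from compound 1 to compound 4 (0.98 log units; beyond the scatter). Compound 4 is estimated at 400 nM, within a range from 60 nM to 5000 nM.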

Compound 4, half-maximal inhibitory concentration: 950 nM
Compound 4: middle estimate off by 2.4-fold (0.38 log units), on the low side; the range from low to high includes it.
By their numbers in this assay, from the lowest: compound 1; then compound 2; then compound 4; then compound 3.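

In this assay, going by these compounds alone, the carboxy to carbamoyl exchange gives a 23-fold higher number from compound 1 to compound 4 (1.35 log units; beyond the scatter), the first reading on this part of the molecule, since every earlier step changed only the aryl group on the benzylic carbon. The 4-carboxycyclohexyl therefore matters to the number and not only the aryl group, even though the exchange swaps a single heavy atom and leaves the computed hydrogen-bond donor and acceptor counts unchanged; the carboxy group is still not essential for measurable inhibition, as compound 4 gives 950 nM. Nothing at hand accounts for the size of this step.

A single amide cannot show which feature of the carboxy group carries the difference; a methyl ester, a tetrazole or a hydroxymethyl group on the same saturated ring carbon would help to separate the possibilities. Within the data shown here, the tail exchange is also seen only with the 3-methylphenyl group of compound 1, so whether it costs as much with the 4-methylphenyl group of compound 2 or the 3-cyanophenyl group of compound 3 remains open.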